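A few compounds are considered here, and "the series" means these few. Any claim that something is new, unique, unknown or untested is made for them only; others in the source may bear on it.

Compound 3 `CC(C)(Sc1ccccc1)C1OCC(C/C=C\CCC(=O)O)C(c2cccnc2)O1` gives 40 nM in an assay for inhibition of Thromboxane-A synthase (Homo sapiens), using microsomes; on this read-out lower numbers stand for stronger inhibition and higher numbers for weaker inhibition. Among the three compounds measured so far it holds the second highest number, and all three lie within the scatter of one another. Compound 1 `O=C(O)CC/C=C\CC1COC(c2ccc3ccccc3c2)OC1c1cccnc1` gives 50 nM in this assay, and compound 2 `CC(C)(Oc1ccccc1O)C1OCC(C/C=C\CCC(=O)O)C(c2cccnc2)O1` gives 32 nM. The two steps that lead to compound 3 are a 1.3-fold lower number from compound 1 to compound 3 (0.10 log units; within the scatter) and a 1.3-fold higher number from compound 2 to compound 3 (0.10 log units; within the scatter); neither rises above the noise of repeated measurement.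

Compound 4 `CC(C)(Cc1ccccc1)C1OCC(C/C=C\CCC(=O)O)C(c2cccnc2)O1` differs from compound 3 by benzyl in place of phenylsulfanyl on a saturated chain carbon bound to two saturated chain carbons and a saturated ring carbon. The step that bears on this change most directly is a 1.3-fold higher number from compound 2 to compound 3 (0.10 log units; within the scatter), which also exchanges the group at this same place and stays within the scatter. The other step, a 1.3-fold lower number from compound 1 to compound 3 (0.10 log units; within the scatter), exchanges a larger group elsewhere and likewise stays within the scatter. No exchange at this place has so far moved the number beyond the scatter, so for compound 4 no step beyond the scatter is expected in this assay in either direction. The expected step is no change at the digits printed from compound 3 to compound 4 (within the scatter). Compound 4 is therefore estimated to give about 40 nM, with a range from 20 nM to 80 nM.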

Compound 4, half-maximal inhibitory concentration: 12 nM
For compound 4 the middle estimate is 3.3-fold (0.52 log units) above the measured one, outside the stated range (below it).
By their numbers in this assay, from the lowest: compound 4; then compounds 2, 3 and 1 (each within the scatter of the next).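

In this assay, the group on the saturated chain carbon bound to two saturated chain carbons and a saturated ring carbon now moves the number beyond the scatter: benzyl in place of phenylsulfanyl gives a 3.3-fold lower number from compound 3 to compound 4 (0.52 log units; beyond the scatter), and benzyl in place of 2-hydroxyphenoxy gives a 2.7-fold lower number from compound 2 to compound 4 (0.43 log units; beyond the scatter), whereas the exchange of 2-hydroxyphenoxy for phenylsulfanyl stayed within the scatter. Phenylsulfanyl and benzyl have the same number of heavy atoms and both have one six-membered aromatic ring of carbon only, so the exchange leaves these counts unchanged, replacing sulfur with carbon and taking the hydrogen-bond acceptor count from 1 to 0. The larger exchange on a saturated ring carbon, 1-benzyl-1-methylethyl in place of naphthalen-2-yl, gives a 4.2-fold lower number from compound 1 to compound 4 (0.62 log units; beyond the scatter), while the group in compound 3 at that same place left the number within the scatter of compound 1.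

The compounds shown offer no measurement that explains these steps. As far as these compounds go, whether a 2-phenylethyl or a benzylamino group at this place would keep the number of compound 4 remains open.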